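From 3-methoxyphenyl to 4-methoxyphenyl: compound 3 awaits measurement

This account rests on a few compounds, and the source may have more. Where it says the series, first, only, none or still open, it means among the compounds named here.

In an ADME assay on THP-1 cells (Homo sapiens) for cytotoxicity, read by MTT assay, with a stated time of 72 h (a lower number here means a stronger inhibitor, a higher number a weaker inhibitor), compound 1 (`COc1cc(/C=C/C(=O)c2c(O)c3ccccc3[nH]c2=O)ccc1O`) gives 23300 nM and compound 2 (`COc1cccc(/C=C/C(=O)c2c(O)c3ccccc3[nH]c2=O)c1`) gives 38500 nM. Among the compounds with values here, these are the only two numbers so far, and they lie within the scatter of each other, so the measurements do not separate compound 2 from compound 1.

Compound 3 (`COc1ccc(/C=C/C(=O)c2c(O)c3ccccc3[nH]c2=O)cc1`) has not yet been measured in this assay. Its difference from compound 2 is 4-methoxyphenyl in place of 3-methoxyphenyl on a double-bonded chain carbon bound to a double-bonded chain carbon.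

Within the data shown here, no measured pair shows this exchange. Among the measured compounds shown here, the single step available, a 1.7-fold higher number from compound 1 to compound 2 (0.22 log units; within the scatter), is a different change, hydrogen in place of hydroxy on an aromatic carbon, so it bears on the question only indirectly. It does show that one edit to this aromatic ring left the number within the scatter. On that slim evidence, no shift beyond the scatter is expected in either direction. The expected step is a 1.3-fold lower number from compound 2 to compound 3 (0.11 log units; within the scatter). Compound 3 is estimated at 30000 nM, with an expected range of 14000 nM to 65000 nM.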

Compound 3, half-maximal inhibitory concentration: > 50000 nM
Compound 3: no number, only a limit; the forecaster's own chance of this, stated with the estimate: 10%; middle value at least 1.6-fold (0.22 log units) away from the limit.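

In this assay compound 3 gives > 50000 nM, which is a limit of the assay and not a number. The exchange of 3-methoxyphenyl for 4-methoxyphenyl, on a double-bonded chain carbon bound to a double-bonded chain carbon, can therefore be read only as a floor: an at least 1.2-fold higher number from compound 2 to compound 3 (0.11 log units; that floor lies within the scatter). This is the first view of this change, which the earlier step, on a different edit, could not give: the methoxy group's new placement brings no lower number than that of compound 2, though whether the true step passes the scatter cannot be told, and the reading stops at a ceiling of the measurement: the limit of > 50000 nM in this assay, at which 1 of the 3 values shown sits.

On these data alone, what stays open is how far beyond the limit the true value of compound 3 lies, and so whether the two methoxyphenyl isomers really differ in this assay. Also open, as far as these compounds go, is whether a different group at this place, such as an aminophenyl or a carboxyphenyl in place of the methoxyphenyl, would move the number beyond the scatter in either direction.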